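This account rests on a few compounds, and the source may have more. Where it says the series, first, only, none or still open, it means among the compounds named here.

Working notes on the series. In a functional assay on HepG2 cells (Homo sapiens) for cytotoxicity, read by WST assay, with a stated time of 24 h (a lower number here means that less compound is tolerated, a higher number that more compound is tolerated), compound 1 `CCCCCC=Cc1cc(-c2ccc3cc(C(=O)O)ccc3c2)ccc1O` gives 2.44 ug/mL and compound 2 `CCCCCC=Cc1cc(-c2ccc3cc(CO)ccc3c2)ccc1O` gives 4.19 ug/mL. These two stand level, as shown by a 1.7-fold higher number from compound 1 to compound 2 (0.23 log units; within the scatter). Compound 3 `Cc1cc(-c2ccc3cc(C(=O)O)ccc3c2)ccc1O` is reported only as a limit, > 32 ug/mL. Compound 4 `CCCCCc1cc(-c2ccc3cc(CO)ccc3c2)ccc1O` has pentyl in place of hept-1-en-1-yl on an aromatic carbon. For the measured compounds named here, the one measured change at this place is an at least 13-fold higher number from compound 1 to compound 3 (1.11 log units; beyond the scatter), where methyl enters on the carboxy member. Pentyl is a longer chain than methyl, so only a small part of that rise is expected in this assay. The expected size is a 1.6-fold higher number from compound 2 to compound 4 (0.19 log units; within the scatter). For compound 4 the estimate is 6.5 ug/mL, with an expected range of 3 ug/mL to 15 ug/mL.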

Compound 4, concentration lethal to 50% of the cells: 3.27 ug/mL
Estimate against measurement, compound 4: 2.0-fold (0.30 log units) above, within the range that was stated.
By their numbers in this assay, from the lowest: compounds 1, 4 and 2 (each within the scatter of the next). At a limit, above all of these: compound 3.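

At this place, ortho to a hydroxy group, the hydroxymethyl member shows a 1.3-fold lower number from compound 2 to compound 4 (0.11 log units; within the scatter) in this assay. Pentyl and hept-1-en-1-yl therefore stand level, so the double bond outside aromatic rings is not needed to keep the number at this level. Compound 3, with methyl on the carboxy member, remains a limit and not a number: the limit of > 32 ug/mL in this assay, at which 1 of the 4 values shown sits.

Open, from the compounds shown here alone, is where between pentyl and methyl the number starts to climb. Also open, going by these compounds, is how a propyl chain, a decyl chain or an amine at this place would read.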